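The compounds below may be only part of what the source reports. "The series", "measured", "known", "first", "only" and "open" are said of these compounds alone.

Measured in a functional assay on MCF7 cells (Homo sapiens) for antiproliferative activity, read by sulforhodamine B assay, with a stated time of 3 days; a higher number here means a weaker inhibitor, a lower number a stronger inhibitor:
Compound 1 `c1ccc2c(c1)COC(n1cnc3c(OCC4CCCCC4)ncnc31)CO2`: 11600 nM
Compound 2 `c1ccc2c(c1)COC(n1cnc3ncnc(OCC4CCCCC4)c31)CO2`: 13400 nM

Within the data shown here, only two compounds have been measured. Compound 2, at 13400 nM, lies within the usual scatter of compound 1, so the two cannot be told apart. Compound 3 `Fc1ccc(Sc2ncnc3ncn(C4COc5ccccc5CO4)c23)cc1` carries (4-fluorophenyl)sulfanyl in place of cyclohexylmethoxy on an aromatic carbon. Among the measured compounds shown here, no measured pair shows this exchange, and no change beyond the scatter is expected in this assay. The expected change is a 1.5-fold lower number from compound 2 to compound 3 (0.17 log units; within the scatter), a size estimated to stay within the scatter. For compound 3 the estimated value is 9000 nM, with an expected range from 3000 nM to 27000 nM.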

Compound 3, half-maximal inhibitory concentration: 14100 nM
Estimate against measurement, compound 3: 1.6-fold (0.19 log units) below; the measured number falls inside the stated range.
By their numbers in this assay, from the lowest: compounds 1, 2 and 3 (each within the scatter of the next).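

In this assay, putting (4-fluorophenyl)sulfanyl in place of cyclohexylmethoxy on this aromatic carbon gives a 1.1-fold higher number from compound 2 to compound 3 (0.02 log units; within the scatter) and so leaves the read-out unmoved. At this position, then, a six-membered aromatic ring carrying fluorine on a sulfur link and a six-membered non-aromatic carbon ring on an oxygen-containing chain cannot be told apart. No measurement shown here offers any explanation for this.

On these data alone, whether any group at this position moves the number beyond the scatter remains open. An amine or a carboxylic acid in place of (4-fluorophenyl)sulfanyl would test this.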